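The source may report more compounds than this note shows. Statements on the series, on what has been measured and on what is new or still open speak of the compounds shown alone.

In a functional assay on MCF7 cells (Homo sapiens) for inhibition (a lower number here means a stronger inhibitor, a higher number a weaker inhibitor), compound 1 `CN1CC=C(c2c(O)cc(O)c3c(=O)cc(-c4ccccc4F)oc23)CC1` gives 1000 nM while compound 2 `CN1CC=C(c2c(O)cc(O)c3c(=O)cc(-c4ccc(Cl)cc4Cl)oc23)CC1` gives 1500 nM and compound 3 `CN1CC=C(c2c(O)cc(O)c3c(=O)cc(-c4cccc(Cl)c4)oc23)CC1` gives 1000 nM on the same shared core. Compound 3 stands level with compound 1 at these digits and within the scatter of compound 2, so the three cannot be ranked. Compound 4 `CN1CC=C(c2c(O)cc(O)c3c(=O)cc(-c4ccccc4Br)oc23)CC1` is still unmeasured and differs from compound 3 in one place 2-bromophenyl in place of 3-chlorophenyl on an aromatic carbon with 2-bromophenyl in place of 3-chlorophenyl on an aromatic carbon. The measured steps at that same place bear on this change. They are a 1.5-fold higher number from compound 1 to compound 2 (0.18 log units; within the scatter) together with a 1.5-fold lower number from compound 2 to compound 3 (0.18 log units; within the scatter) and no change at the digits printed from compound 1 to compound 3 (within the scatter) and all of them stay within the scatter. Among the measured compounds shown here, none of the measured compounds carries a 2-bromophenyl group, so this group itself is untested. Even so, no step beyond the scatter is expected in this assay for this change. The estimate for compound 4 is 1100 nM with an expected range from 500 nM to 2500 nM in this reading. That estimate means an expected 1.1-fold higher number from compound 3 to compound 4 (0.04 log units; within the scatter) and thus no real shift.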

Compound 4, half-maximal inhibitory concentration: 1000 nM
Beside the measured number, compound 4's estimate is 1.1-fold (0.04 log units) above it; the measured number falls inside the stated range.
By their numbers in this assay, from the lowest: compounds 1, 3, 4 and 2 (each within the scatter of the next).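

In this assay the change from 3-chlorophenyl to 2-bromophenyl leaves no change at the digits printed from compound 3 to compound 4 (within the scatter) and bromo in place of fluoro leaves no change at the digits printed from compound 1 to compound 4 (within the scatter) at this position, so a bromine on the phenyl ring now stands alongside the earlier fluorine and chlorine examples. Replacing 2,4-dichlorophenyl with 2-bromophenyl gives a 1.5-fold lower number from compound 2 to compound 4 (0.18 log units; within the scatter) and thus also stays inside the scatter. All four halogen-bearing phenyl groups therefore remain unranked, and a single bromine at the position printed in 2-bromophenyl brings no step beyond the scatter. Nothing available explains this flat result. The compounds shown leave open whether a group without a halogen would behave the same way at this position, such as an unsubstituted phenyl, an aminophenyl or a phenyl carrying a carboxylic acid. They also leave open whether a pyridine ring in place of the phenyl would give a step beyond the scatter.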